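The compounds below may be only part of what the source reports. "The series", "measured", "known", "first", "only" and "open" are said of these compounds alone.

Working notes on the series. In an assay on cells for inhibition of HSP60/HSP10 (Homo sapiens), with a stated time of 60 min (on this read-out lower numbers stand for stronger inhibition and higher numbers for weaker inhibition), compound 1 `O=S(=O)(Nc1ccc(-c2nc3ccccc3o2)cc1)c1ccc(F)c(C(F)(F)F)c1` gives 28000 nM. Compound 2 `O=S(=O)(Nc1ccc2oc(-c3ccccc3)nc2c1)c1ccc(Cl)cc1` returns a limit of the assay rather than a number, > 100000 nM. Compound 3 `O=S(=O)(Nc1ccc2oc(-c3ccccc3)nc2c1)c1ccc(Cl)c(C(F)(F)F)c1` also returns a limit, > 100000 nM. The step that the two limits leave unreadable from compound 2 to compound 3 therefore has no readable size. On the numbers shown, compound 2 stands at the limit of > 100000 nM in this assay, at which 2 of the 3 values shown sit, and has no value of its own to compare.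

Compound 4 `CCc1ccc(S(=O)(=O)Nc2ccc3oc(-c4ccccc4)nc3c2)cc1` differs from compound 2 by ethyl in place of chloro on an aromatic carbon. For the measured compounds named here, no measured step exchanges a chloro for an ethyl, and the one step on the shared core of compound 2 and compound 3 cannot be sized, so no measured step bears on this change with a known magnitude. Going by the values given here, the only number in this assay belongs to compound 1, whose core differs. The step that the limit leaves unreadable from compound 2 to compound 4 is expected to be small or unreadable. Compound 4 is estimated at 150000 nM, within a range from 40000 nM to 600000 nM, and a further limit is expected to be the most likely outcome.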

Compound 4, half-maximal inhibitory concentration: > 100000 nM
Compound 4 gave a limit, no number; the forecaster's own chance of this, stated with the estimate: 70%; the middle value lies beyond the limit too.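

Compound 2 and compound 4 both return limits of the assay, so no step can be read between them: the limit of > 100000 nM in this assay, at which 3 of the 4 values shown sit.

The compounds shown leave open whether any change on the shared core of compound 2, compound 3 and compound 4 gives a readable value in this assay at all.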